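Replacing hydroxy with methyl on a retinoid-like naphthoic acid series

The source may hold more compounds than are shown below. What is called first, only, known or untested is meant among the compounds shown, and "the series" means these compounds.

The study concerns four compounds that share a tetramethyl-tetrahydronaphthalene unit joined to a naphthoic acid. Compound 1 `CC1(C)CCC(C)(C)c2cc(C(=O)c3ccc4cc(C(=O)O)ccc4c3)c(O)cc21` was tested in an assay on isolated protein with retinoic acid receptor gamma (Homo sapiens) as the target (a higher number here means a larger maximal response, a lower number a smaller maximal response), and compound 1 gives 70%. Compound 2 `Cc1cc2c(cc1C(=O)c1ccc3cc(C(=O)O)ccc3c1)C(C)(C)CCC2(C)C` differs from compound 1 by the change (methyl in place of hydroxy on an aromatic carbon), and in this assay compound 2 gives 58%, a step of a number 12 percentage points lower from compound 1 to compound 2 (beyond the scatter). Compound 3 `CC1(C)CCC(C)(C)c2cc(C(O)c3ccc4cc(C(=O)O)ccc4c3)c(O)cc21` carries a carbinol in place of the ketone; the difference between the cores of compound 1 and compound 3 is not broken down here. In this assay compound 3 gives 47%, the lowest of the three measured values.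

Compound 4 `Cc1cc2c(cc1C(O)c1ccc3cc(C(=O)O)ccc3c1)C(C)(C)CCC2(C)C` has not yet been measured. It differs from compound 3 by methyl in place of hydroxy on an aromatic carbon, the same change seen once before between compound 1 and compound 2. Because that earlier step was a number 12 percentage points lower from compound 1 to compound 2 (beyond the scatter), the same change on the core of compound 3 is expected to give a step of about a number 12 percentage points lower from compound 3 to compound 4 (beyond the scatter). On that basis compound 4 is estimated to reach 35% in this assay, with a likely range from 22% to 48%.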

Compound 4, largest response reached (reported as maximum), in percent of the reference or control that the assay uses: 82%
For compound 4 the middle estimate is 47 percentage points below the measured one; the measured number lies above the stated range.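

In this assay, methyl in place of hydroxy on an aromatic carbon gives a number 35 percentage points higher from compound 3 to compound 4 (beyond the scatter), and the same change behaves differently on the two cores: the same change on two cores in this assay, a number 12 percentage points lower (beyond the scatter) from compound 1 to compound 2 and a number 35 percentage points higher (beyond the scatter) from compound 3 to compound 4, 47 percentage points apart, beyond the scatter of two such steps. Across these two pairs, then, the direction and size of the step seen on the core of compound 1 do not carry over to the core of compound 3, so a step measured on one core is a poor guide to the other here. Among these compounds, this does not show why the two steps differ, and with only two pairs in one assay it sets no general rule for the series.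

The compounds shown leave open how a methoxy group, an amine or an ethyl group on that same aromatic carbon would behave on either core. They also leave open whether the opposite steps would persist if an amine or a methylene took the place of the carbonyl or carbinol.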